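From naphthalen-1-yl to 3,5-dimethyl-1,2-oxazol-4-yl

A few compounds are considered here, and "the series" means these few. Any claim that something is new, unique, unknown or untested is made for them only; others in the source may bear on it.

In a functional assay on MDA-MB-436 cells (Homo sapiens) for antiproliferative activity, read by MTT assay, with a stated time of 48 h (on this read-out lower numbers stand for stronger inhibition and higher numbers for weaker inhibition), compound 1 (`C=CS(=O)(=O)N1CCN(c2ccn3ncc(-c4ccccc4)c3n2)CC1`) stands at 19500 nM while compound 2 (`C=CS(=O)(=O)N1CCN(c2ncnc3sc(-c4ccc(N5CCN(C)CC5)cc4)cc23)CC1`) stands at 8760 nM and compound 3 (`C=CS(=O)(=O)N1CCN(c2ncnc3sc(-c4cccc5ccccc45)cc23)CC1`) stands at 28100 nM on the same read-out. Compound 3 cannot be told apart from compound 1, since their two numbers lie within the usual scatter of repeated measurements. Compound 2 has a lower number than compound 3 by more than that scatter, which means stronger inhibition.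

Compound 4 (`C=CS(=O)(=O)N1CCN(c2ncnc3sc(-c4c(C)noc4C)cc23)CC1`) has 3,5-dimethyl-1,2-oxazol-4-yl in place of naphthalen-1-yl on an aromatic carbon. This carbon belongs to a five-membered aromatic ring with 1 sulfur, next to the ring sulfur. Within the data shown here, no measured pair shows this swap, so the only guide is the modest spread of the three numbers so far. In this assay an estimated step of a 1.4-fold lower number from compound 3 to compound 4 (0.15 log units; within the scatter) is expected, leaning slightly towards a lower number but with no shift beyond the scatter. Compound 4 is therefore expected at 20000 nM within a range from 8000 nM to 50000 nM when measured.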

Compound 4, half-maximal inhibitory concentration: 34600 nM
The estimate for compound 4 lay 1.7-fold (0.24 log units) below the measured number, within the range that was stated.
By their numbers in this assay, from the lowest: compound 2; then compounds 1, 3 and 4 (each within the scatter of the next).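

Among these compounds, replacing naphthalen-1-yl with 3,5-dimethyl-1,2-oxazol-4-yl gives a 1.2-fold higher number from compound 3 to compound 4 (0.09 log units; within the scatter) in this assay, the first direct comparison at this aromatic carbon of the five-membered ring with 1 sulfur. The change is a large one on paper: two six-membered aromatic rings of carbon only leave, while one five-membered aromatic ring with 2 hetero atoms and 2 hydrogen-bond acceptors enters. Even so, this single swap does not move the number beyond the usual scatter, so the two groups cannot be told apart here. No measurement available here explains why they read alike.

One pair at one position says little about other kinds of group. On these data alone, whether a carboxylic acid or a longer alkyl chain on this carbon would shift the number beyond the scatter remains open.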